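Chloro for fluoro: working notes on compound 3

A few compounds are considered here, and "the series" means these few. Any claim that something is new, unique, unknown or untested is made for them only; others in the source may bear on it.

Compound 1 `Cc1cc(CNS(=O)(=O)c2ccc([N+](=O)[O-])cc2)c(C)s1`: > 204000 nM
Compound 2 `Cc1cc(CNS(=O)(=O)c2ccc(F)cc2)c(C)s1`: "not determined" (no result reported)

In an ADME assay on MDCK cells (Canis lupus familiaris) for cytotoxicity, read by MTT assay, with a stated time of 24 h (on this read-out higher numbers stand for lower toxicity in this test and lower numbers for higher toxicity in this test), compound 1 gives > 204000 nM, which is a limit of the assay and not a number. Compound 2 has no single number and reads "not determined" (no result reported). The only reference point in the series is the limit of > 204000 nM in this assay, at which 1 of the 2 values shown sits.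

Next is compound 3 `Cc1cc(CNS(=O)(=O)c2ccc(Cl)cc2)c(C)s1`. The structural change is chloro in place of fluoro on an aromatic carbon, para to a large group. Going by the values given here, no measured step is available, and no step beyond the usual scatter is expected in this assay, in either direction. For compound 3 the estimated value is 200000 nM, with an expected range from 80000 nM to 400000 nM.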

Compound 3, half-maximal cytotoxic concentration: 52900 nM
Estimate against measurement, compound 3: 3.8-fold (0.58 log units) above, outside the stated range (below it).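

Chloro in place of nitro on an aromatic carbon, para to a large group, gives an at least 3.8-fold lower number from compound 1 to compound 3 (0.58 log units; beyond the scatter) in this assay, so a change at this position can move the read-out towards higher toxicity in this test. The step from fluoro to chloro cannot be read, as compound 2 has no result. The entry for compound 1 is a limit of the assay and not a number, so the full size of the step stays unknown: the limit of > 204000 nM in this assay, at which 1 of the 3 values shown sits.

The compounds shown leave open where compound 2 would fall relative to compound 1 and compound 3. From the compounds shown here alone, how an amine or a methoxy group at this position would read also remains open.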